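From 3,5-dimethylphenyl to 3,5-dichlorophenyl on the shared core

This account rests on a few compounds, and the source may have more. Where it says the series, first, only, none or still open, it means among the compounds named here.

In a functional assay on HL-60 cells (Homo sapiens) for inhibition, read by MTT assay, with a stated time of 72 h (on this read-out higher numbers stand for weaker inhibition and lower numbers for stronger inhibition), compound 1 `COc1cccc(N2CCN(C(=O)c3oc(C)nc3-c3ccccc3)CC2)c1` gives 34.8 nM, compound 2 `CCOc1cccc(N2CCN(C(=O)c3oc(C)nc3-c3ccccc3)CC2)c1` gives 151 nM and compound 3 `Cc1cc(C)cc(N2CCN(C(=O)c3oc(C)nc3-c3ccccc3)CC2)c1` gives 34.5 nM. Compound 3 therefore stands at the low end of these numbers, a place it shares with compound 1.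

Compound 4 `Cc1nc(-c2ccccc2)c(C(=O)N2CCN(c3cc(Cl)cc(Cl)c3)CC2)o1` keeps the shared core and has 3,5-dichlorophenyl in place of 3,5-dimethylphenyl on an amine nitrogen in a ring. Going by the values given here, no measured step introduces chlorine, so the evidence is indirect.

The same ring nitrogen carries the group changed in all three measured steps. The exchange of 3-methoxyphenyl for 3,5-dimethylphenyl gives a 1.0-fold lower number from compound 1 to compound 3 (0.00 log units; within the scatter). The two steps beyond the scatter, a 4.3-fold higher number from compound 1 to compound 2 (0.64 log units; beyond the scatter) and a 4.4-fold lower number from compound 2 to compound 3 (0.64 log units; beyond the scatter), are both modest and both involve the 3-ethoxyphenyl group, which is absent from compound 4.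

From the compounds shown here alone, no step beyond the scatter is therefore expected in this assay, and the direction stays open. The expected step is a 1.2-fold higher number from compound 3 to compound 4 (0.06 log units; within the scatter). For compound 4 the estimate is 40 nM, with an expected range of 14 nM to 120 nM.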

Compound 4, half-maximal inhibitory concentration: 41.8 nM
The estimate for compound 4 lay 1.0-fold (0.02 log units) below the measured number; measured number inside the range.
By their numbers in this assay, from the lowest: compounds 3, 1 and 4 (each within the scatter of the next); then compound 2.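

Compound 4 is the only chlorine-bearing compound shown, and in this assay swapping methyl for chlorine on the aryl group at this ring nitrogen gives a 1.2-fold higher number from compound 3 to compound 4 (0.08 log units; within the scatter); the comparison with the methoxy compound gives a 1.2-fold higher number from compound 1 to compound 4 (0.08 log units; within the scatter). Compound 2 stands further apart with a third comparison, a 3.6-fold lower number from compound 2 to compound 4 (0.56 log units; beyond the scatter), leaving 3-ethoxyphenyl as the only group shown here that is set off from the others, while 3-methoxyphenyl, 3,5-dimethylphenyl and 3,5-dichlorophenyl lie within the scatter of one another. Nothing shown accounts for this pattern.

From the compounds shown here alone, whether a phenyl ring carrying an amine, a carboxylic acid or a chain longer than ethoxy would stay with these three groups or fall with compound 2 remains open. Also open, going by these compounds, is whether 3,5-dichlorophenyl and 3,5-dimethylphenyl would still match if the shared core were changed.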